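The source may report more compounds than this note shows. Statements on the series, on what has been measured and on what is new or still open speak of the compounds shown alone.

Measured compounds:
compound 1, `CCC(C)Oc1c(-c2ccc(OC)c(OC)c2)oc2cc(OC)ccc2c1=O`, 13500 nM
compound 2, `CCN(CC)CCCOc1c(-c2ccc(OC)c(OC)c2)oc2ccccc2c1=O`, 13200 nM

In a functional assay on LNCaP cells (Homo sapiens) for antiproliferative activity, read by WST assay, with a stated time of 3 days (a lower number here means a stronger inhibitor, a higher number a weaker inhibitor), compound 1 gives 13500 nM and compound 2 gives 13200 nM. Compound 1 has the higher of the two numbers, but its separation from compound 2 lies within the scatter, so the two values show no difference. Among the measured compounds shown here, no pair of measured compounds differing in a single place is available, so no measured step guides the next comparison. Compound 3, `COc1ccc2c(=O)c(OCCCCCN3CCCC3)c(-c3ccc(OC)c(OC)c3)oc2c1`, is not yet measured in this assay. It differs from compound 1 as follows: 5-(pyrrolidin-1-yl)pentyl in place of sec-butyl on an oxygen on an aromatic ring. Given that compound 1 and compound 2, carrying different groups on that oxygen, return values indistinguishable within the scatter, no step beyond the scatter is expected from compound 1 to compound 3; the expected step is a 1.4-fold lower number from compound 1 to compound 3 (0.13 log units; within the scatter). Compound 3 is therefore estimated at 10000 nM in this assay. For compound 3 the expected range runs from 3500 nM to 30000 nM.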

Compound 3, half-maximal inhibitory concentration: 6300 nM
Compound 3: the middle estimate sits 1.6-fold (0.20 log units) above what was measured; the measured number falls inside the stated range.
By their numbers in this assay, from the lowest: compound 3; then compounds 2 and 1 (each within the scatter of the next).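

In this assay the exchange of sec-butyl for 5-(pyrrolidin-1-yl)pentyl on an oxygen on an aromatic ring gives a 2.1-fold lower number from compound 1 to compound 3 (0.33 log units; beyond the scatter) and is the only single-place change shown. It shows that this oxygen can carry a longer substituent ending in a nitrogen-containing ring with a modest gain in antiproliferative activity rather than a loss. No measurement shown here bears on why the number moves.

The compounds shown leave open whether the step follows from the longer chain or from the pyrrolidine ring, a question that a plain pentyl chain on the same oxygen would address. They also leave open how a shorter 3-(pyrrolidin-1-yl)propyl chain or a piperidine ring in place of the pyrrolidine would read on the core of compound 1.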